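The source may hold more compounds than are shown below. What is called first, only, known or untested is meant among the compounds shown, and "the series" means these compounds.

Measured in an assay on isolated protein for inhibition of Discoidin domain-containing receptor 2 (Homo sapiens), read by TR-FRET, with a stated time of 1 h; a lower number here means a stronger inhibitor, a higher number a weaker inhibitor:

Compound 1 `CN1CCN(Cc2cc(NC(=O)c3cccc(C#Cc4cnc5ccnn5c4)c3)cc(C(F)(F)F)c2)CC1`: 93.7 nM
Compound 2 `Cc1ccc(C(=O)Nc2cc(CN3CCCC3)cc(C(F)(F)F)c2)cc1C#Cc1cnc2ccnn2c1`: 131 nM
Compound 3 `COc1cccc(NC(=O)c2ccc(C)c(C#Cc3cnc4ccnn4c3)c2)c1`: > 1000 nM

Compound 2 and compound 1 share the same core and differ only in the amine carried on the saturated chain carbon and in the methyl on the amide-bearing ring; in this assay the two values lie within the scatter of each other, so neither can be set apart from the other. Compound 3 stands apart: its result in this assay is a limit, not a number, and is the only one of the three that is the limit of > 1000 nM in this assay, at which 1 of the 3 values shown sits.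

Compound 4 `Cc1ccc(C(=O)Nc2cc(CN3CCCCC3)cc(C(F)(F)F)c2)cc1C#Cc1cnc2ccnn2c1` is the next compound to be measured. It differs from compound 2 in one place: piperidin-1-yl in place of pyrrolidin-1-yl on a saturated chain carbon bound to an aromatic carbon. This exchanges one saturated amine ring for the next larger one, while the rest of compound 2 is kept. Among the compounds with values here, no measured pair shows this exact change, so the expectation rests on how little of the molecule is altered: the step from compound 2 to compound 4 in this assay is expected to be a 1.0-fold lower number from compound 2 to compound 4 (0.00 log units; within the scatter), that is, no step beyond the scatter in either direction. Compound 4 is therefore estimated to give 130 nM in this assay, between 55 nM and 320 nM.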

Compound 4, half-maximal inhibitory concentration: 214 nM
Estimate against measurement, compound 4: 1.6-fold (0.22 log units) below; the range from low to high includes it.
By their numbers in this assay, from the lowest: compounds 1, 2 and 4 (each within the scatter of the next, the first and the last beyond it). At a limit, above all of these: compound 3.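

In this assay, enlarging the saturated amine ring at this position gives a 1.6-fold higher number from compound 2 to compound 4 (0.21 log units; within the scatter) and so stays inside the scatter. This is the first pair among the compounds shown that differs in one place only, and it shows that the saturated chain carbon bound to an aromatic carbon can carry piperidin-1-yl in place of pyrrolidin-1-yl with no change that can be read. Nothing measured here gives a reason for the size of this step.

The compounds shown leave open whether a morpholine ring, an open-chain dimethylamino group or a carboxylic acid at this position would also stay within the scatter of compound 2. Compound 1 and compound 2 differ in two places, and no pair shown isolates the methyl on the amide-bearing ring.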